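Stereochemical Variants of a Hydroxylated Piperidine Carboxylic Acid

The source may hold more compounds than are shown below. What is called first, only, known or untested is meant among the compounds shown, and "the series" means these compounds.

Measured compounds:
compound 1 `O=C(O)[C@H]1NC[C@@H](O)[C@H](O)[C@H]1O` gives 6.3%
compound 2 `O=C(O)[C@H]1NC[C@@H](O)[C@@H](O)[C@@H]1O` gives 28%

In an assay on isolated protein for inhibition of cytosolic endo-beta-N-acetylglucosaminidase (Homo sapiens), tested at 1000 uM (a lower number here means less inhibition, a higher number more inhibition at the concentration tested (going by the name of the read-out)), compound 1 stands lowest of the two numbers; its nearest neighbour is compound 2, and the step of a number 21.7 percentage points higher from compound 1 to compound 2 (beyond the scatter) lies beyond the scatter. That step is the only one known, and it rests on (the fact that compounds 1 and 2 differ only in the configuration as drawn), so it shows that a change of configuration alone can move the read-out by a modest amount. Compound 3 `O=C(O)[C@@H]1NC[C@@H](O)[C@H](O)[C@@H]1O` has not yet been measured. It differs from compound 1 thus: the two compounds have the same atoms and bonds and differ only in configuration as drawn: 2 of 4 stereo elements differ; a stereocentre at a saturated ring carbon is drawn S in compound 1 and R in compound 3; a stereocentre at a saturated ring carbon is drawn S in compound 1 and R in compound 3. The change is of the same kind as that between compound 1 and compound 2, though at a different pair of ring carbons, so the step to compound 3 is expected to be at most modest and upward, and it may well stay within the scatter. For compound 3 the estimated value is 15%, with a range from 3% to 40%, corresponding to an expected step of a number 8.7 percentage points higher from compound 1 to compound 3 (within the scatter).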

Compound 3, a percentage reported as inhibition, at one concentration (the size of the read-out at that concentration, not a potency): 0.8%
For compound 3 the middle estimate is 14.2 percentage points above the measured one; measured number outside the range, below it.
By their numbers in this assay, from the lowest: compounds 3 and 1 (each within the scatter of the next); then compound 2.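

In this assay, redrawing two stereocentres of compound 1 at a different pair of ring carbons gives a number 5.5 percentage points lower from compound 1 to compound 3 (within the scatter), so this change, unlike the earlier one in a number 21.7 percentage points higher from compound 1 to compound 2 (beyond the scatter), does not separate the two compounds. Set against compound 2, the same kind of change gives a number 27.2 percentage points lower from compound 2 to compound 3 (beyond the scatter), which leaves compound 2 alone above the other two, and that gap rests on configuration only: the fact that compounds 2 and 3 differ only in the configuration as drawn Among these three compounds, then, redrawing two stereocentres does not by itself raise the read-out, and the outcome depends on which two are redrawn: the fact that compounds 1 and 3 differ only in the configuration as drawn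

Going by these compounds, all three compounds keep the carboxylic acid, so it remains open whether a methyl ester or a primary amide in its place, or a longer chain on the nitrogen, would alter the read-out in any of these configurations. On these data alone, every step here also changes two stereocentres at once, and what each single stereocentre contributes stays open.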